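This account rests on a few compounds, and the source may have more. Where it says the series, first, only, none or still open, it means among the compounds named here.

Compound 2 `COc1ccccc1NC(=O)c1ccc(/N=N\c2c[nH]c3ccccc23)cc1` carries a 2-methoxyphenyl on the amide-type nitrogen. In a functional assay on P388 cells (Mus musculus) for inhibition, read by MTT assay, with a stated time of 72 h (on this read-out lower numbers stand for stronger inhibition and higher numbers for weaker inhibition), compound 2 was reported as "not active" (no number reported), with no number given, so it stands without a value on this read-out, while compound 1 `Cc1ccc(NC(=O)c2ccc(/N=N\c3c[nH]c4ccccc34)cc2)cc1` in this assay gives 300 nM. Compound 3 `Cc1cccc(NC(=O)c2ccc(/N=N\c3c[nH]c4ccccc34)cc2)c1` has not yet been measured in this assay. It differs from compound 2 by 3-methylphenyl in place of 2-methoxyphenyl on an amide-type nitrogen. Within the data shown here, with no number for compound 2, no step can be computed, but compound 3 shares with compound 1 a methyl substituent on the phenyl that sits on the amide-type nitrogen, and compound 1 in this assay gives 300 nM. Compound 3 is therefore expected to regain measurable inhibition, though it may remain weaker than compound 1. The estimate for compound 3 in this assay is 800 nM, within a range from 200 nM to 5000 nM.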

Compound 3, half-maximal inhibitory concentration: 300 nM
Compound 3: the middle estimate sits 2.7-fold (0.43 log units) above what was measured; measured number inside the range.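

In this assay, 3-methylphenyl in place of 4-methylphenyl on the amide-type nitrogen gives no change at the digits printed from compound 1 to compound 3 (within the scatter), so the two methylphenyl groups cannot be told apart at this position on this read-out. Compound 3 has a number where compound 2, with 2-methoxyphenyl, was reported as not active, so not every substituted phenyl at this position gives a measurable value, although the step between these two cannot be read. Nothing available explains this difference.

The compounds shown do not separate the methoxy group from its place on the ring, as compound 2 differs from compound 3 in both. From the compounds shown here alone, how an amine or a carboxylic acid on this phenyl, or a longer chain in place of the methyl, would read in this assay also stays open.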